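Sulfonyl-sulfur substituent changes in a weak inhibitor series

The source may hold more compounds than are shown below. What is called first, only, known or untested is meant among the compounds shown, and "the series" means these compounds.

Measured so far:
compound 1 `O=S(=O)(Nc1ccc(-c2nc3ccccc3o2)cc1)c1cccc(O)c1` — 62000 nM
compound 2 `O=S(=O)(Nc1ccc(-c2nc3ccccc3o2)cc1)c1cccs1` — 63000 nM

In an assay on cells for inhibition of HSP60/HSP10 (Homo sapiens), with a stated time of 60 min (on this read-out lower numbers stand for stronger inhibition and higher numbers for weaker inhibition), compound 1 gives 62000 nM and compound 2 gives 63000 nM. Compound 2 stands at one of two numbers that lie within the scatter of each other; the step of a 1.0-fold higher number from compound 1 to compound 2 (0.01 log units; within the scatter) is within the scatter, so the two compounds cannot be told apart on this read-out. Compound 3 `COc1ccc(Cl)cc1S(=O)(=O)Nc1ccc(-c2nc3ccccc3o2)cc1` has not been measured. It differs from compound 2 as follows: 5-chloro-2-methoxyphenyl in place of thiophen-2-yl on a sulfonyl sulfur. Among the compounds with values here, the single measured step, a 1.0-fold higher number from compound 1 to compound 2 (0.01 log units; within the scatter), bears directly on this change, since it also exchanged the group on the sulfonyl sulfur, and it produced no movement beyond the scatter. One step is thin ground, but on it no change beyond the scatter is expected in this assay for compound 3, so the expected step is no change at the digits printed from compound 2 to compound 3 (within the scatter). Compound 3 is therefore estimated at 63000 nM, with a range of 20000 nM to 150000 nM.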

Compound 3, half-maximal inhibitory concentration: > 100000 nM
Compound 3 was reported as a limit (the forecaster's own chance of this, stated with the estimate: 15%); middle value at least 1.5-fold (0.20 log units) from the limit.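

In this assay compound 3 is reported as a limit and not as a number: the limit of > 100000 nM in this assay, at which 1 of the 3 values shown sits.

This position now holds a group that gives no number on this read-out, so the flat pair of thiophen-2-yl and 3-hydroxyphenyl no longer describes all the groups shown here. The steps can be read only as floors, with an at least 1.5-fold higher number from compound 2 to compound 3 (0.20 log units; that floor lies within the scatter) and also an at least 1.6-fold higher number from compound 1 to compound 3 (0.20 log units; that floor lies within the scatter) as the two readings. Neither floor goes beyond the scatter, so 5-chloro-2-methoxyphenyl is not shown to weaken inhibition, though the true values could lie well beyond it.

Still open, on these data alone, is whether the methoxy or the chlorine on the phenyl ring matters more, as a phenyl carrying only one of them would show. Also open, as far as these compounds go, is how a carboxylic acid or an amine on that ring would read in this assay.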